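The source may report more compounds than this note shows. Statements on the series, on what has been measured and on what is new or still open speak of the compounds shown alone.

In a functional assay on HepG2 cells (Homo sapiens) for cytotoxicity, read by MTT assay, with a stated time of 48 h (a higher number here means a weaker inhibitor, a lower number a stronger inhibitor), two compounds have been measured so far. Compound 1 `CCCCCCCCNC(=O)[C@@H](NC(=O)/C=C/c1ccccc1)[C@@H](C)O` gives 55600 nM in this assay. Compound 2 `CCCCCCCCCCCCCCNC(=O)[C@@H](NC(=O)c1cc2ccccc2o1)[C@@H](C)O` gives 23400 nM in this assay, the lower of the two numbers, and its gap to compound 1 lies beyond the usual scatter, so compound 2 stands as the stronger inhibitor of the pair. Within the data shown here, the two differ in two places at once, in the acyl group on one amide nitrogen and in the length of the alkyl chain on the other, so no step between measured compounds that differ in a single place is available.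

Compound 3 `CCCCCCCCCCCCCCNC(=O)[C@@H](NC(=O)/C=C/c1ccccc1)[C@@H](C)O` has not yet been measured. It differs from compound 2 in one place: 2-phenylethenyl in place of 1-benzofuran-2-yl on a carbonyl carbon. Compound 1 already carries the 2-phenylethenyl group and gives 55600 nM, while compound 2 carries the (1-benzofuran-2-yl)carbonyl group together with the longer chain and gives 23400 nM; nothing shows which of the two changes carries that difference. The step of a 1.4-fold higher number from compound 2 to compound 3 (0.14 log units; within the scatter) is therefore expected to be small, toward a weaker inhibitor, and possibly within the scatter. Compound 3 is expected to give about 32000 nM in this assay, within 12000 nM to 80000 nM.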

Compound 3, half-maximal inhibitory concentration: 150000 nM
Compound 3: the middle estimate sits 4.7-fold (0.67 log units) below what was measured, and the stated range ends below it.
By their numbers in this assay, from the lowest: compound 2; then compound 1; then compound 3.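

In this assay, the acyl change can now be read on its own: with the long chain held fixed, 2-phenylethenyl in place of 1-benzofuran-2-yl on a carbonyl carbon gives a 6.4-fold higher number from compound 2 to compound 3 (0.81 log units; beyond the scatter), so of these two groups 1-benzofuran-2-yl goes with the stronger inhibitor. The chain can also be read on its own: with 2-phenylethenyl held fixed, hexyl in place of hydrogen on a saturated chain carbon, eight bonds along the chain from an amide-type nitrogen, gives a 2.7-fold higher number from compound 1 to compound 3 (0.43 log units; beyond the scatter), so here the longer chain goes with the weaker inhibitor. No measurement at hand offers an explanation for either step.

As far as these compounds go, whether the longer chain has the same effect when 1-benzofuran-2-yl sits on the carbonyl carbon remains open, since the chain step has been read only with 2-phenylethenyl. Among these compounds, also open are how a chain of intermediate length would compare, since only two lengths appear here, and whether a 2-phenylethyl group, which lacks the double bond outside the aromatic ring, would stand closer to 2-phenylethenyl or to 1-benzofuran-2-yl.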